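Swapping the aryl group on a sulfonyl: from compound 2 to 3

A few compounds are considered here, and "the series" means these few. Any claim that something is new, unique, unknown or untested is made for them only; others in the source may bear on it.

Compound 1 `COc1cc2nc(N3CCN(S(=O)(=O)c4ccc(C)cc4)CC3)nc(N)c2cc1OC` and compound 2 `COc1cc2nc(N3CCN(S(=O)(=O)c4ccc(C(F)(F)F)cc4)CC3)nc(N)c2cc1OC` share one core and differ only in the group on the aromatic ring attached to the sulfonyl sulfur. In a functional assay on PC-3 cells (Homo sapiens) for inhibition (on this read-out lower numbers stand for stronger inhibition and higher numbers for weaker inhibition), compound 1 gives 30000 nM, and in this assay compound 2 gives 27000 nM. For the measured compounds named here, the change of a 1.1-fold lower number from compound 1 to compound 2 (0.05 log units; within the scatter) lies within the scatter, so on the two numbers so far compound 2 sits alongside compound 1 rather than apart from it.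

Compound 3 `COc1cc2nc(N3CCN(S(=O)(=O)c4cc(Cl)ccc4Cl)CC3)nc(N)c2cc1OC` is not yet measured. It differs from compound 2 by 2,5-dichlorophenyl in place of 4-(trifluoromethyl)phenyl on a sulfonyl sulfur. Going by the values given here, the only step that bears on this place, a 1.1-fold lower number from compound 1 to compound 2 (0.05 log units; within the scatter), changed nothing beyond the scatter when one aryl group replaced another on the same sulfonyl sulfur. The step of a 1.0-fold higher number from compound 2 to compound 3 (0.02 log units; within the scatter) is therefore expected to stay within the scatter as well. Compound 3 is estimated at 28000 nM, with a range from 10000 nM to 80000 nM.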

Compound 3, half-maximal inhibitory concentration: 60000 nM
Beside the measured number, compound 3's estimate is 2.1-fold (0.33 log units) below it, and the stated range covers the measured number.
By their numbers in this assay, from the lowest: compounds 2, 1 and 3 (each within the scatter of the next, the first and the last beyond it).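

In this assay, for the compounds shown here, the aryl group on the sulfonyl sulfur now shows a first, small influence: 2,5-dichlorophenyl in place of 4-(trifluoromethyl)phenyl gives a 2.2-fold higher number from compound 2 to compound 3 (0.35 log units; beyond the scatter) and this is the first step at this place to clear the scatter, though only modestly. Set against the 4-methylphenyl group, the same 2,5-dichlorophenyl group gives a 2.0-fold higher number from compound 1 to compound 3 (0.30 log units; within the scatter) and so stays within the scatter, which means the change stands out against only one of the two earlier compounds. No measurement at hand explains this difference.

On these data alone, all three aryl groups carry only methyl, trifluoromethyl or chlorine, so the response of this assay to a ring bearing an amine or a carboxylic acid stays open. Also open, as far as these compounds go, is whether a single chlorine would match the pair, or how a longer alkyl chain in place of the aryl group would fare.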